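Amide-terminus variation on the piperidine sulfonamide series

The compounds below may be only part of what the source reports. "The series", "measured", "known", "first", "only" and "open" are said of these compounds alone.

Compound 1 `CCN(CC)S(=O)(=O)c1ccc(S(=O)(=O)N2CCC[C@@H](C(=O)N[C@H]3CC[C@H](OC)CC3)C2)cc1` sits second highest of the three numbers in a functional assay on MIA PaCa-2 cells (Homo sapiens) for inhibition, read by MTT assay, with a stated time of 7 days (on this read-out lower numbers stand for stronger inhibition and higher numbers for weaker inhibition), where compound 1 gives 1350 nM. Compound 2 `CCN(CC)S(=O)(=O)c1ccc(S(=O)(=O)N2CCC[C@@H](C(=O)N[C@H]3CCOC3)C2)cc1` gives 1670 nM and compound 3 `CCN(CC)S(=O)(=O)c1ccc(S(=O)(=O)N2CCC[C@@H](C(=O)N[C@@H]3CCOC3)C2)cc1` gives 750 nM. The step of a 1.2-fold higher number from compound 1 to compound 2 (0.09 log units; within the scatter) and the step of a 1.8-fold lower number from compound 1 to compound 3 (0.26 log units; within the scatter) both stay within the scatter, while a 2.2-fold lower number from compound 2 to compound 3 (0.35 log units; beyond the scatter) is modest and rests on (the fact that compounds 2 and 3 differ only in the configuration as drawn). Compound 4 `CCN(CC)S(=O)(=O)c1ccc(S(=O)(=O)N2CCC[C@@H](C(=O)N3CCS(=O)(=O)CC3)C2)cc1` carries the change (1,1-dioxothiomorpholin-4-yl in place of (4-methoxycyclohexyl)amino on a carbonyl carbon). For the measured compounds named here, no measured step exchanges the amide nitrogen itself for a ring nitrogen, so the nearest guidance is that changing the group on the amide-type nitrogen moved the numbers little. Compound 4 is therefore expected to land near compound 1, with no step beyond the scatter, as a 1.3-fold higher number from compound 1 to compound 4 (0.12 log units; within the scatter). The estimate for compound 4 is 1800 nM, between 700 nM and 4500 nM.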

Compound 4, half-maximal inhibitory concentration: 900 nM
Compound 4: the middle estimate sits 2.0-fold (0.30 log units) above what was measured, within the range that was stated.
By their numbers in this assay, from the lowest: compounds 3, 4, 1 and 2 (each within the scatter of the next, the first and the last beyond it).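

Placing 1,1-dioxothiomorpholin-4-yl on the carbonyl carbon gives the first compound in the series with no hydrogen-bond donor in this group and no stereocentre in it, yet all three steps stay within the scatter: a 1.5-fold lower number from compound 1 to compound 4 (0.18 log units; within the scatter), a 1.2-fold higher number from compound 3 to compound 4 (0.08 log units; within the scatter) and a 1.9-fold lower number from compound 2 to compound 4 (0.27 log units; within the scatter). The amide hydrogen is therefore not required for a number in this range, at least with this ring. Nothing on hand accounts for these steps.

Going by these compounds, whether morpholin-4-yl or an open-chain diethylamino group on the same carbonyl carbon would also stay in this range remains open.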